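The source may hold more compounds than are shown below. What is called first, only, known or untested is meant among the compounds shown, and "the series" means these compounds.

In an assay on HeLa cells for displacement of a labelled ligand from 5-hydroxytryptamine receptor 6 (Homo sapiens) (a higher number here means a weaker inhibitor, a lower number a stronger inhibitor), compound 1 `CN1CCN(c2cn(S(=O)(=O)c3ccc(F)cc3)c3ccc(Br)cc23)CC1` gives 9.2 nM. Compound 2 `CCN1CCN(c2cn(S(=O)(=O)c3ccc(F)cc3)c3ccc(Br)cc23)CC1` gives 10.6 nM in this assay, and the step of a 1.2-fold higher number from compound 1 to compound 2 (0.06 log units; within the scatter) is within the scatter, so compound 2 and compound 1 stand together. Compound 3 `CCN1CCN(c2cn(S(=O)(=O)c3ccc(F)cc3)c3ccc(Cl)cc23)CC1` carries chloro in place of bromo on an aromatic carbon. Among the measured compounds shown here, the only measured step, a 1.2-fold higher number from compound 1 to compound 2 (0.06 log units; within the scatter), concerns the amine nitrogen in a ring and not this halogen, so it offers no direct guide; an exchange of one halogen for another at this place is expected to shift the number in this assay by no more than the scatter. Compound 3 is therefore expected near 13 nM, between 5 nM and 32 nM, a step of a 1.2-fold higher number from compound 2 to compound 3 (0.09 log units; within the scatter).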

Compound 3, inhibition constant: 10.7 nM
The estimate for compound 3 lay 1.2-fold (0.08 log units) above the measured number; the measured number falls inside the stated range.
By their numbers in this assay, from the lowest: compounds 1, 2 and 3 (each within the scatter of the next).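

In this assay, chloro in place of bromo on an aromatic carbon gives a 1.0-fold higher number from compound 2 to compound 3 (0.00 log units; within the scatter). This shows that the exchange of these two halogens at this place leaves the number within the scatter, something the earlier step, made on the saturated chain on the amine nitrogen in a ring, could not show. Nothing at hand explains this result. The compounds shown leave open whether a methoxy, a nitrile or an amine at this aromatic carbon would stand with these halogens. They also leave open how a longer chain, such as propyl, on the amine nitrogen would stand.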